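Seven Carbons Rearranged: From Cycloheptyl to Methylcyclohexyl

The compounds below may be only part of what the source reports. "The series", "measured", "known", "first", "only" and "open" are said of these compounds alone.

The measured compounds:
Compound 1, `CCCCN(C)c1cncc(C(=O)NC2CCCCCC2)n1`, in a physicochemical assay for lipophilicity (a higher number here means a more lipophilic compound, a lower number a more polar compound), compound 1 gives 3.8.
Compound 2, `O=C(NCC1CC1)c1cncc(N2CCCN(Cc3ccccc3)CC2)n1`, in this assay compound 2 gives 3.
Compound 3, `O=C(NC1CCCCCC1)c1cnc(N2CCCCC2)cn1`, in this assay compound 3 gives 3.9.

Compound 3 sits at the upper end of these three numbers. Its nearest neighbour is compound 1, whose value lies within the usual scatter of it, so the two cannot be ordered. Compound 2 lies furthest away, and that gap is beyond the scatter, so compound 3 is clearly the more lipophilic of those two.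

Compound 4, `C[C@H]1CC[C@H](NC(=O)c2cnc(N3CCCCC3)cn2)CC1`, is not yet measured. It differs from compound 3 in one place: 4-methylcyclohexyl in place of cycloheptyl on an amide-type nitrogen. The two compounds hold the same atoms joined differently, with the carbon count of the group on the amide nitrogen unchanged. Within the data shown here, no measured pair in this set isolates such a swap, so there is no step to lean on. With nothing added or removed, the step of no change at the digits printed from compound 3 to compound 4 (within the scatter) is expected to stay within the scatter, in no firm direction. Compound 4 is therefore estimated at 3.9, with a range from 3.5 to 4.3.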

Compound 4, distribution coefficient: 4.4
Compound 4: the middle estimate sits 0.50 log units below what was measured, and the stated range ends below it.
By their numbers in this assay, from the lowest: compound 2; then compounds 1 and 3 (each within the scatter of the next); then compound 4.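

In this assay, among these compounds, putting 4-methylcyclohexyl in place of cycloheptyl on an amide-type nitrogen gives a number 0.50 log units higher from compound 3 to compound 4 (beyond the scatter), and this is the first step in the set that isolates a single change. It shows that the read-out at this position responds to how the carbons are arranged and not only to how many there are: both groups hold 7 heavy atoms, all carbon, with no hydrogen-bond donors or acceptors and no net charge, yet their numbers part. Nothing measured here accounts for the step.

A single pair cannot separate the change in ring size from the methyl branch or the defined stereocentres. From the compounds shown here alone, it remains open how a plain cyclohexyl, the other stereoisomer of 4-methylcyclohexyl, or a ring carrying a hydroxyl or an amine would read in this assay.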